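Trimming the Benzyl Carbamate of Compound 3 to Isobutyl

A few compounds are considered here, and "the series" means these few. Any claim that something is new, unique, unknown or untested is made for them only; others in the source may bear on it.

Compound 1, `Cc1cc(C(=O)Nc2c(F)cccc2F)nn1Cc1cc(Cl)ccc1OCc1ccccc1`, gives 10 nM in an assay on CHO-K1 cells for displacement of a labelled ligand from prostaglandin E2 receptor EP1 subtype (Homo sapiens); on this read-out higher numbers stand for weaker inhibition and lower numbers for stronger inhibition.
Compound 2, `Cc1cc(NC(=O)C2CCCC2)nn1Cc1cc(Cl)ccc1OCc1ccccc1`, gives 15.9 nM in this assay.
Compound 3, `Cc1cc(NC(=O)OCc2ccccc2)nn1Cc1cc(Cl)ccc1OCc1ccccc1`, gives 79.4 nM in this assay.

The three compounds share one core and differ only in the group attached to its aromatic carbon. Compound 3 carries the highest number of the three: the step of a 7.9-fold higher number from compound 1 to compound 3 (0.90 log units; beyond the scatter) and the step of a 5.0-fold higher number from compound 2 to compound 3 (0.70 log units; beyond the scatter) both run upward beyond the scatter, while a 1.6-fold higher number from compound 1 to compound 2 (0.20 log units; within the scatter) stays within it. Compound 4, `Cc1cc(NC(=O)OCC(C)C)nn1Cc1cc(Cl)ccc1OCc1ccccc1`, keeps the carbamate of compound 3 and alters only its outer end: isopropyl in place of phenyl on a saturated chain carbon bound to an oxygen next to a carbonyl group. Going by the values given here, no measured step exchanges one group for another on this saturated chain carbon, so the forecast leans indirectly on the step from compound 2 to compound 3, where a carbonyl bound directly to cyclopentyl gave the lower number. In compound 4 the aromatic ring leaves, yet the oxygen next to the carbonyl remains, so the number is expected to stay close to that of compound 3; the estimated step is a 1.3-fold lower number from compound 3 to compound 4 (0.10 log units; within the scatter). Compound 4 is therefore estimated at 63 nM in this assay, probably between 20 nM and 200 nM.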

Compound 4, half-maximal inhibitory concentration: 25.1 nM
Compound 4: the middle estimate sits 2.5-fold (0.40 log units) above what was measured; low and high end bracket the measured number.
By their numbers in this assay, from the lowest: compounds 1, 2 and 4 (each within the scatter of the next, the first and the last beyond it); then compound 3.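

In this assay the outer end of the carbamate matters in its own right: with the carbamate kept, isopropyl in place of phenyl on this saturated chain carbon gives a 3.2-fold lower number from compound 3 to compound 4 (0.50 log units; beyond the scatter) and this step lies beyond the scatter. The carbamate link therefore does not by itself set the higher number of compound 3, as a 1.6-fold higher number from compound 2 to compound 4 (0.20 log units; within the scatter) stays within the scatter, while a 2.5-fold higher number from compound 1 to compound 4 (0.40 log units; beyond the scatter) shows that compound 1 still keeps a lower number than compound 4. No measurement at hand explains why the exchange of phenyl for isopropyl lowers the number.

On these data alone, it remains open whether a cyclohexyl on this carbon would behave like the phenyl or like the isopropyl. Also open, as far as these compounds go, is how a longer chain, or an amine at the outer end, would shift the number.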